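Adding a Carbonyl to Compound 2: Expected Lipophilicity

The source may hold more compounds than are shown below. What is called first, only, known or untested is meant among the compounds shown, and "the series" means these compounds.

Of the compounds shown here, two have so far been measured in a physicochemical assay for lipophilicity, read by HPLC, measured as octanol-water partition; a lower number here means a more polar compound, a higher number a more lipophilic compound. Compound 1 `COc1ccc(/C=C/c2ccc(OCCCC(C)(C)C(=O)O)cc2)cc1` gives 6.08 in this assay. Compound 2 `CC(C)(Oc1ccc(CCCOc2ccc(/C=C/c3ccccc3)cc2)cc1)C(=O)O` gives 7.44 in this assay. Compound 2 therefore stands highest of the two numbers, and its nearest neighbour, compound 1, lies lower by a margin that goes beyond the usual scatter of the measurement.

Compound 3 `CC(C)(Oc1ccc(CCCOc2ccc(C(=O)/C=C/c3ccccc3)cc2)cc1)C(=O)O` has not yet been measured. It differs from compound 2 in one place: (2-phenylethenyl)carbonyl in place of 2-phenylethenyl on an aromatic carbon. The group that leaves carries no hydrogen-bond acceptor, whereas the group that enters brings one hydrogen-bond acceptor and one further double bond outside the aromatic rings.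

Within the data shown here, no pair of measured compounds shows this particular change, so there is no measured step to lean on; the expectation rests on the change itself. The expected step of a number 0.94 log units lower from compound 2 to compound 3 (beyond the scatter) in this assay is a fall that goes beyond the scatter. Compound 3 is thus estimated at 6.5 in this assay, with a range from 5.9 to 7.1.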

Compound 3, partition coefficient: 6.55
The estimate for compound 3 lay 0.05 log units below the measured number, and the stated range covers the measured number.
By their numbers in this assay, from the lowest: compound 1; then compound 3; then compound 2.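

Among these compounds, compound 3 supplies the first measured single-place step in this set: in this assay, the change in which 2-phenylethenyl leaves and (2-phenylethenyl)carbonyl enters on an aromatic carbon, para to a large group, gives a number 0.89 log units lower from compound 2 to compound 3 (beyond the scatter). Compound 1 and compound 2 differ in more than one place, so they could not isolate the effect of any one change, whereas here the rest of compound 2 stays the same and the step can be tied to this exchange alone. Nothing measured here explains the fall, so the data record its size but not its origin.

As far as these compounds go, this is one step at one position, so it remains open whether the same exchange would give a step of similar size on the core of compound 1 or at another place on the aromatic ring. From the compounds shown here alone, it also remains open whether an amide or a sulfonyl group carrying the 2-phenylethenyl group at this position would give a comparable step in this assay, or whether the fall is specific to the carbonyl.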